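The source may hold more compounds than are shown below. What is called first, only, known or untested is meant among the compounds shown, and "the series" means these compounds.

Measured in a functional assay on HT-29 cells (Homo sapiens) for inhibition, read by sulforhodamine B assay, with a stated time of 72 h; a lower number here means a stronger inhibitor, a higher number a weaker inhibitor:
- compound 1 `CCOc1ccc(C2C(C3CC3)C(=O)N2c2cc(OC)c(OC)c(OC)c2)cc1` gives 63 nM
- compound 2 `COc1ccc(C2C(C3CC3)C(=O)N2c2cc(OC)c(OC)c(OC)c2)cc1` gives 107 nM
- compound 3 `COc1cc(N2C(=O)C(C3CC3)C2c2ccc(SC)cc2)cc(OC)c1OC` gives 204 nM

Compound 1 stands clear of the scatter on one step only (a 3.2-fold higher number from compound 1 to compound 3 (0.51 log units; beyond the scatter)). The other (a 1.7-fold higher number from compound 1 to compound 2 (0.23 log units; within the scatter)) does not clear it. Next comes compound 4 `CCOc1ccc(C2CC(=O)N2c2cc(OC)c(OC)c(OC)c2)cc1`, with hydrogen in place of cyclopropyl on a saturated ring carbon. Among the compounds with values here, no measured step touches that ring carbon: all three, including the remaining one (a 1.9-fold higher number from compound 2 to compound 3 (0.28 log units; within the scatter)), change only the group on the aromatic ring, and every measured compound keeps the cyclopropyl. Their sizes therefore offer no direct guide. A higher number is expected in this assay, with wide uncertainty. The expected change is a 6.3-fold higher number from compound 1 to compound 4 (0.80 log units; beyond the scatter). For compound 4 the estimate is 400 nM (expected range 80 nM to 2500 nM).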

Compound 4, half-maximal inhibitory concentration: 65 nM
Compound 4: the middle estimate sits 6.2-fold (0.79 log units) above what was measured, and the stated range ends above it.
By their numbers in this assay, from the lowest: compounds 1, 4, 2 and 3 (each within the scatter of the next, the first and the last beyond it).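

In this assay, within the data shown here, hydrogen in place of cyclopropyl on the saturated ring carbon gives a 1.0-fold higher number from compound 1 to compound 4 (0.01 log units; within the scatter), the first step at this position. With the 4-ethoxyphenyl group kept, the cyclopropyl is therefore not needed to hold the number of compound 1 in this assay. No measurement available here explains this result.

Open, as far as these compounds go, is whether this ring carbon also tolerates an amine, a carboxylic acid or a longer chain. Also open, from the compounds shown here alone, is whether hydrogen matches cyclopropyl when methoxy or methylsulfanyl replaces the ethoxy on the aromatic ring.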